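This account rests on a few compounds, and the source may have more. Where it says the series, first, only, none or still open, it means among the compounds named here.

In an ADME assay on HEL cells (Homo sapiens) for cytotoxicity, with a stated time of 3 days (a lower number here means that less compound is tolerated, a higher number that more compound is tolerated), compound 3 `Cc1cc(N2CCN(C)CC2)cn2c(CSCCc3ccccc3)cnc12` gives 32 ug/mL. This lies within the scatter of both compound 2 `Cc1cc(-c2ccc3[nH]ccc3c2)cn2c(CSCCc3ccccc3)cnc12` at 26 ug/mL and compound 1 `C=Cc1ccc(-c2cc(C)c3ncc(CSCc4ccccc4)n3c2)cc1` at 59 ug/mL. The next structure is compound 4 `Cc1cc(-n2ccc3ccccc32)cn2c(CSCCc3ccccc3)cnc12`, which has 1H-indol-1-yl in place of 4-methylpiperazin-1-yl on an aromatic carbon.

Among the compounds with values here, one measured step bears directly on this change, as it concerns the same place on the core: a 1.2-fold higher number from compound 2 to compound 3 (0.09 log units; within the scatter). It exchanges 1H-indol-5-yl for 4-methylpiperazin-1-yl and stays within the scatter. Compound 2 is the closest reference for compound 4, since both carry an indolyl group at this place, and compound 2 gives 26 ug/mL. Within the data shown here, no measured compound carries 1H-indol-1-yl itself, so the effect of the indole attachment point remains unknown, and the range has to stay wide.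

Among the measured compounds shown here, with only this one small step as a guide, no change beyond the scatter is expected in this assay. The expected result is a 1.2-fold lower number from compound 3 to compound 4 (0.07 log units; within the scatter), with any drift more likely towards the value of compound 2 than away from it. For compound 4 the estimated value is 27 ug/mL, with an expected range of 11 ug/mL to 60 ug/mL.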

Compound 4, half-maximal cytotoxic concentration: 18 ug/mL
Compound 4: the middle estimate sits 1.5-fold (0.18 log units) above what was measured; the measured number falls inside the stated range.
By their numbers in this assay, from the lowest: compounds 4, 2, 3 and 1 (each within the scatter of the next, the first and the last beyond it).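

In this assay, this place on the aromatic carbon, two atoms from the ring nitrogen, now holds three different groups, and neither new step leaves the scatter: a 1.8-fold lower number from compound 3 to compound 4 (0.25 log units; within the scatter), and a 1.4-fold lower number from compound 2 to compound 4 (0.16 log units; within the scatter). The first step adds to the earlier comparison by exchanging a six-membered non-aromatic ring with 2 hetero atoms for 1H-indol-1-yl, and the second shows that the indole attachment point, unknown until now, produces no readable change here, so neither the type of ring nor the attachment point separates these compounds in this read-out. No experimental information is available to explain these numbers.

As far as these compounds go, whether this place stays as flat in this assay with a much smaller or charged substituent, such as a carboxylic acid, a primary amine or a short alkyl chain, remains open, as the three groups compared here are all ring systems of similar size. From the compounds shown here alone, the contribution of the sulfur-containing chain also remains open, as the shared phenethyl thioether is held constant across compound 2, compound 3 and compound 4.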